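Methoxy for Fluoro Where Both Parents Show Only Limits

This account rests on a few compounds, and the source may have more. Where it says the series, first, only, none or still open, it means among the compounds named here.

Compound 1 `N#Cc1ccc(Nc2nc(Oc3ccnc4ccccc34)nc(N3CCN(c4ccc(F)cc4)CC3)n2)cc1C(F)(F)F` was tested in a functional assay on DU-145 cells (Homo sapiens) for cytotoxicity, read by sulforhodamine B assay, with a stated time of 48 h; on this read-out higher numbers stand for lower toxicity in this test and lower numbers for higher toxicity in this test. In this assay compound 1 gives > 100000 nM, which is a limit of the assay and not a number. Compound 2 `N#Cc1ccc(Nc2nc(Oc3ccnc4ccccc34)nc(N3CCC(Cc4ccccc4)CC3)n2)cc1C(F)(F)F` was examined in the same way. In this assay compound 2 gives > 100000 nM, again a limit rather than a number. Within the data shown here, compound 1 thus stands at the limit together with the only other value shown, as the limit of > 100000 nM in this assay, at which 2 of the 2 values shown sit, records, and no measured step exists to compound 2. Compound 3 `COc1ccc(N2CCN(c3nc(Nc4ccc(C#N)c(C(F)(F)F)c4)nc(Oc4ccnc5ccccc45)n3)CC2)cc1` differs from compound 1 by one change: methoxy in place of fluoro on an aromatic carbon, para to a large group. With both known values sitting at the limit, the expected step is none beyond the scatter, in no set direction: a number no higher from compound 1 to compound 3 (the limit leaves the size open). Compound 3 is therefore expected to give 100000 nM, with a range from 30000 nM to 300000 nM.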

Compound 3, concentration lethal to 50% of the cells: > 100000 nM
Compound 3: no number, only a limit (the forecaster's own chance of this, stated with the estimate: 85%); the middle value sits exactly at the limit.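

No new step can be read between compound 1 and compound 3, as each shows only a limit of the assay and not a number: the limit of > 100000 nM in this assay, at which 3 of the 3 values shown sit.

The compounds shown leave open whether methoxy in place of fluoro changes anything in this assay, and how far the true values of compound 1 and compound 3 lie past that limit.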